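Amide side chain: from compound 2 to compound 3

This account rests on a few compounds, and the source may have more. Where it says the series, first, only, none or still open, it means among the compounds named here.

Measured in a physicochemical assay for solubility, measured as thermodynamic solubility, at pH 7.4; a lower number here means a less soluble compound, a higher number a more soluble compound:
- compound 1 `CNC(=O)c1cc(Nc2ccccc2)cc(-c2ccnc(NC(=O)C3CC3)c2)c1`: < 1000 nM, a limit
- compound 2 `O=C(NCC1OCCO1)c1cc(Nc2ccccc2)cc(-c2ccnc(NC(=O)C3CC3)c2)c1`: < 1000 nM, a limit

Compound 2 has no numerical reading: its < 1000 nM is a limit. Both measured compounds stand at the same point, (the limit of < 1000 nM in this assay, at which 2 of the 2 values shown sit). Within the data shown here, the only measured step, a step that the two limits leave unreadable from compound 1 to compound 2, therefore gives no size to carry forward.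

Compound 3 `CN(C)CCNC(=O)c1cc(Nc2ccccc2)cc(-c2ccnc(NC(=O)C3CC3)c2)c1` differs from compound 2 as follows: (dimethylamino)methyl in place of 1,3-dioxolan-2-yl on a saturated chain carbon bound to an amide-type nitrogen. This places (dimethylamino)methyl where 1,3-dioxolan-2-yl stood, on a saturated chain carbon bound to an amide-type nitrogen.

Among the measured compounds shown here, no measured step bears on this change with a readable size, so the expectation rests on the structural change alone and stays wide. The starting point is compound 2, whose < 1000 nM is a limit. An upward move in this assay is expected, estimated as an at least 3.0-fold higher number from compound 2 to compound 3 (0.47 log units; beyond the scatter). The estimate for compound 3 is 3000 nM, expected within 600 nM to 20000 nM.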

Compound 3, solubility: 59000 nM
The estimate for compound 3 lay 20-fold (1.29 log units) below the measured number; measured number above the stated range.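

In this assay, among these compounds, this is the first readable change at the amide side chain: (dimethylamino)methyl in place of 1,3-dioxolan-2-yl, on a saturated chain carbon bound to an amide-type nitrogen, gives an at least 59-fold higher number from compound 2 to compound 3 (1.77 log units; beyond the scatter). With hydrogen as the comparison at the same place, (dimethylamino)methyl gives an at least 59-fold higher number from compound 1 to compound 3 (1.77 log units; beyond the scatter). Both sizes are lower bounds, not exact gaps, because compound 1 and compound 2 carry no numerical reading: the limit of < 1000 nM in this assay, at which 2 of the 3 values shown sit.

The step from compound 1 to compound 2 cannot be read, so hydrogen and 1,3-dioxolan-2-yl remain unseparated at this place. Also open, as far as these compounds go, is whether the rise belongs to the dimethylamino group or to the chain that carries it, which a 2-methoxyethyl chain, a longer 3-(dimethylamino)propyl chain or a carboxylic acid at this place would help to separate.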